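The source may report more compounds than this note shows. Statements on the series, on what has been measured and on what is new or still open speak of the compounds shown alone.

Three compounds built on one shared core were tested in a functional assay on CHO-K1 cells for antagonist activity at C-X-C chemokine receptor type 3 (Homo sapiens), read by FLIPR, with a stated time of 10 min; on this read-out lower numbers stand for stronger inhibition and higher numbers for weaker inhibition. Compound 1 `CCOc1ncc(-c2nc(C(F)(F)F)sc2N2CCN(C(=O)Cn3ncc4cccnc43)[C@H](C)C2)cn1` gives 4.1 nM. Compound 2 `CCOc1ncc(-c2nc(C(F)(F)F)sc2N2CCN(C(=O)Cn3nc(C)nc3C)[C@H](C)C2)cn1` gives 7 nM, and compound 3 `CCOc1ncc(-c2nc(C(F)(F)F)sc2N2CCN(C(=O)Cn3cc(Cl)cn3)[C@H](C)C2)cn1` gives 5.1 nM. On these numbers compound 2 stands highest, yet the steps of a 1.7-fold higher number from compound 1 to compound 2 (0.23 log units; within the scatter) and a 1.4-fold lower number from compound 2 to compound 3 (0.14 log units; within the scatter) both lie within the scatter, as does a 1.2-fold higher number from compound 1 to compound 3 (0.09 log units; within the scatter).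

Compound 4 `Cc1nc(C)n(CC(=O)N2CCN(c3sc(C(F)(F)F)nc3-c3cnc(N4CCCC4)nc3)C[C@H]2C)n1` differs from compound 2 by pyrrolidin-1-yl in place of ethoxy on an aromatic carbon. Going by the values given here, none of the measured steps touches that place: all three swap the group on the saturated chain carbon bound to the carbonyl carbon, and each stayed within the scatter, so they give no direct guide. With nothing at this position to rest on, compound 4 is expected to land near compound 2. The estimate for compound 4 is 7 nM, with a range from 2.5 nM to 20 nM. That estimate means an expected step of no change at the digits printed from compound 2 to compound 4 (within the scatter).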

Compound 4, half-maximal inhibitory concentration: 3.5 nM
The estimate for compound 4 lay 2.0-fold (0.30 log units) above the measured number; measured number inside the range.
By their numbers in this assay, from the lowest: compounds 4, 1, 3 and 2 (each within the scatter of the next).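

Going by these compounds alone, this is the first look at the place between two ring nitrogen atoms, since the earlier steps all changed the group on the saturated chain carbon. In this assay, pyrrolidin-1-yl in place of ethoxy gives a 2.0-fold lower number from compound 2 to compound 4 (0.30 log units; within the scatter), so this place holds either group within the scatter. Nothing measured here gives a reason for this result.

From the compounds shown here alone, whether a morpholin-4-yl or dimethylamino group would fit this place equally well stays open. So does whether pyrrolidin-1-yl behaves the same way alongside the chain-carbon groups of compound 1 or compound 3.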